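Swapping the triazole's aryl group: bromine replaces methyl

A few compounds are considered here, and "the series" means these few. Any claim that something is new, unique, unknown or untested is made for them only; others in the source may bear on it.

Of the compounds shown here, two of a shared core have been measured in a functional assay on A549 cells (Homo sapiens) for cytotoxicity, read by MTT assay, with a stated time of 72 h; on this read-out higher numbers stand for weaker inhibition and lower numbers for stronger inhibition. Compound 1 `COc1cc2c(Oc3ccc(NC(=O)c4cn(-c5ccccc5)nn4)cc3F)ccnc2cc1OCCCN1CCCC1` gives 360 nM in this assay. Compound 2 `COc1cc2c(Oc3ccc(NC(=O)c4cn(-c5ccccc5C)nn4)cc3F)ccnc2cc1OCCCN1CCCC1` differs from compound 1 only by a methyl in place of hydrogen on an aromatic carbon; in this assay compound 2 gives 900 nM. That change reads a 2.5-fold higher number from compound 1 to compound 2 (0.40 log units; beyond the scatter), so compound 2 stands as the higher of the two numbers, the one showing weaker inhibition.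

Compound 3 `COc1cc2c(Oc3ccc(NC(=O)c4cn(-c5ccc(Br)cc5)nn4)cc3F)ccnc2cc1OCCCN1CCCC1` is not yet measured. It differs from compound 2 by 4-bromophenyl in place of 2-methylphenyl on an aromatic nitrogen. For the measured compounds named here, only one measured step bears on this: the introduction of the methyl from compound 1 to compound 2 raised the number modestly, and compound 3 gives that methyl up. Nothing in the data shows what a bromine on the aryl ring does on its own, so the expected outcome is a number somewhat below that of compound 2, close to compound 1, with wide uncertainty. The expected step is a 2.0-fold lower number from compound 2 to compound 3 (0.30 log units; within the scatter). Compound 3 is therefore estimated at 450 nM, within a range from 150 nM to 1400 nM.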

Compound 3, half-maximal inhibitory concentration: 370 nM
For compound 3 the middle estimate is 1.2-fold (0.09 log units) above the measured one; the measured number falls inside the stated range.
By their numbers in this assay, from the lowest: compounds 1 and 3 (each within the scatter of the next); then compound 2.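

In this assay, the swap of 2-methylphenyl for 4-bromophenyl on the aromatic nitrogen gives a 2.4-fold lower number from compound 2 to compound 3 (0.39 log units; beyond the scatter), and this single step changes both the kind of group on the ring and its place there. Adding the bromine to the plain phenyl ring gives a 1.0-fold higher number from compound 1 to compound 3 (0.01 log units; within the scatter), which means that compound 1 and compound 3 cannot be told apart here, and that a substituent on this ring does not always carry the shift seen with the methyl in compound 2. Nothing in the available data explains why the methyl and the bromine part ways in this read-out.

The compounds shown leave open whether the gap follows the kind of group or its place on the ring, a question that a pair such as 4-methylphenyl and 2-bromophenyl would settle. Also open, as far as these compounds go, is how other groups on this ring would read in the same assay, for example a methoxy, a nitrile or an amine, and whether a saturated ring such as cyclohexyl could take the place of the phenyl ring.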